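Removing the methoxy from a compound at the limit

The source may report more compounds than this note shows. Statements on the series, on what has been measured and on what is new or still open speak of the compounds shown alone.

Measured so far in a functional assay on MIA PaCa-2 cells (Homo sapiens) for cytotoxicity, read by WST assay, with a stated time of 48 h; a higher number here means a weaker inhibitor, a lower number a stronger inhibitor:
- Compound 1 `COc1ccc2c(/C=C(\C#N)C(=O)c3c[nH]c4cc(OC)ccc34)c[nH]c2c1` gives > 50000 nM (a limit)
- Compound 2 `COc1ccc2c(C(=O)/C(C#N)=C/c3c[nH]c4cc(F)ccc34)c[nH]c2c1` gives > 50000 nM (a limit)
- Compound 3 `COc1ccc2c(C(=O)/C(C#N)=C/c3c[nH]c4ccc(OC)cc34)c[nH]c2c1` gives > 50000 nM (a limit)

Compound 3 has no exact number in this assay and stands at > 50000 nM, which is a limit of the assay. It shares this position with the other two compounds, as the record shows (the limit of > 50000 nM in this assay, at which 3 of the 3 values shown sit).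

Compound 4 `COc1ccc2c(C(=O)/C(C#N)=C/c3c[nH]c4ccccc34)c[nH]c2c1` differs from compound 3 in a single place (hydrogen in place of methoxy on an aromatic carbon), with hydrogen in place of methoxy on an aromatic carbon. The closest measured change is a step that the two limits leave unreadable from compound 1 to compound 2, which also removes a methoxy from an aromatic carbon but gives no size to carry over. No step beyond the scatter is therefore expected in this assay, and a further reading at the limit is the likeliest result.

Compound 4 is estimated at 60000 nM in this assay, with an expected range from 20000 nM to 200000 nM as its plausible span. The expected change is a step that the limit leaves unreadable from compound 3 to compound 4 as an estimate only.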

Compound 4, half-maximal inhibitory concentration: > 50000 nM
Compound 4 ended at the assay's limit; the forecaster's own chance of this, stated with the estimate: 75%; the middle value lies beyond the limit too.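

In this assay compound 4 gives > 50000 nM, which is a limit of the assay. Its steps from compound 1, compound 2 and compound 3 cannot be read. The compounds shown leave open whether any change on the shared core would give an exact reading: the limit of > 50000 nM in this assay, at which 4 of the 4 values shown sit.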